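Swapping the aryl group on compound 3 toward a bromo methoxy variant

The source may hold more compounds than are shown below. What is called first, only, known or untested is meant among the compounds shown, and "the series" means these compounds.

Measured compounds:
compound 1 `C[C@H]1CC[C@@H]2[C@@H](OC(=O)[C@]23CC(c2ccc([N+](=O)[O-])cc2)=NO3)[C@]2(C)C(=O)C=C[C@@]12O` 1.37
compound 2 `COc1cc(C2=NO[C@]3(C2)C(=O)O[C@@H]2[C@H]3CC[C@H](C)[C@]3(O)C=CC(=O)[C@@]23C)ccc1O` 0.75
compound 3 `C[C@H]1CC[C@@H]2[C@@H](OC(=O)[C@]23CC(c2ccc(F)cc2)N(c2ccccc2)O3)[C@]2(C)C(=O)C=C[C@@]12O` 3.35

In a physicochemical assay for lipophilicity (on this read-out higher numbers stand for higher lipophilicity and lower numbers for lower lipophilicity), compound 3 gives 3.35, the highest of the three numbers; compound 1 lies nearest with 1.37, and compound 2 furthest with 0.75, both gaps beyond the scatter. Compound 4 `COc1ccc(C2C[C@@]3(ON2c2ccccc2)C(=O)O[C@@H]2[C@H]3CC[C@H](C)[C@]3(O)C=CC(=O)[C@@]23C)cc1Br` has not been measured. It differs from compound 3 in one place: 3-bromo-4-methoxyphenyl in place of 4-fluorophenyl on a saturated ring carbon. Going by the values given here, the only measured step, a number 0.62 log units lower from compound 1 to compound 2 (beyond the scatter), also exchanges one aryl group for another, but on a different carbon and with different groups, so it gives only a rough sense of how far such an exchange can move this assay. Among the compounds with values here, with no closer precedent, compound 4 is expected to stay in the region of compound 3, with a step of a number 0.35 log units higher from compound 3 to compound 4 (beyond the scatter) considered the likely outcome. The estimate for compound 4 is 3.7, within a range from 3.2 to 4.3.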

Compound 4, partition coefficient: 3.98
The estimate for compound 4 lay 0.28 log units below the measured number; low and high end bracket the measured number.
By their numbers in this assay, from the lowest: compound 2; then compound 1; then compound 3; then compound 4.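

On the saturated ring carbon next to the ring nitrogen, 3-bromo-4-methoxyphenyl in place of 4-fluorophenyl gives in this assay a number 0.63 log units higher from compound 3 to compound 4 (beyond the scatter) and so shows that the aryl group at this position can shift the read-out beyond the scatter. The earlier step, a number 0.62 log units lower from compound 1 to compound 2 (beyond the scatter) on a carbon with a double bond to nitrogen, went the other way with different groups, so the two steps share neither position nor direction. No measurement shown here accounts for the rise.

Since the bromine and the methoxy enter together, the compounds shown leave open what each contributes alone. They also leave open how this assay would respond at this position to an aryl group carrying an amine or a carboxylic acid.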